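Adding a Fluoro Group to Compound 1

A few compounds are considered here, and "the series" means these few. Any claim that something is new, unique, unknown or untested is made for them only; others in the source may bear on it.

In a functional assay on HepG2 cells (Homo sapiens) for inhibition, read by MTT assay, with a stated time of 48 h (a lower number here means a stronger inhibitor, a higher number a weaker inhibitor), compound 1 (`c1ccc(-c2ccnc3c2c(-c2ccccc2)nn3-c2ccccc2)cc1`) gives 3210 nM and compound 2 (`O=C(C=CNc1cc(-c2ccccc2)nn1-c1ccccc1)c1ccccc1`) gives 2660 nM as its number. Going by the values given here, those are the only two measurements so far, and they lie within the usual scatter of each other, so compound 1 stands level with compound 2 despite their different structures.

Compound 3 (`Fc1ccc(-c2ccnc3c2c(-c2ccccc2)nn3-c2ccccc2)cc1`) keeps the core of compound 1 and differs from it in one place: fluoro in place of hydrogen on an aromatic carbon. In words, this is fluoro in place of hydrogen on an aromatic carbon, para to a large group, which turns a phenyl into a 4-fluorophenyl.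

Among the compounds with values here, no measured pair differs in a single place, so the data give no direct guide to the size of this step. With one fluoro group as the whole change, no shift beyond the scatter is expected in this assay, and no direction can be argued. The expectation therefore starts from compound 1 at 3210 nM and stays wide. The expected 1.1-fold lower number from compound 1 to compound 3 (0.03 log units; within the scatter) is small. For compound 3 the estimated value is 3000 nM with an expected range of 1200 nM to 7500 nM.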

Compound 3, half-maximal inhibitory concentration: 1570 nM
Compound 3: the middle estimate sits 1.9-fold (0.28 log units) above what was measured, within the range that was stated.
By their numbers in this assay, from the lowest: compounds 3, 2 and 1 (each within the scatter of the next, the first and the last beyond it).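

In this assay the change from hydrogen to fluoro on an aromatic carbon, para to a large group, gives a 2.0-fold lower number from compound 1 to compound 3 (0.31 log units; beyond the scatter) and this modest step lies beyond the usual scatter. Going by these compounds alone, this is the first pair in the set to differ in one place, and it shows that the number can move when only this position is changed, with phenyl becoming 4-fluorophenyl and the rest of compound 1 left intact. Nothing available accounts for the size or the direction of this step.

The compounds shown leave open whether this step is particular to fluoro or would also appear with chloro, methoxy or an amine on the same carbon, and a single substitution gives no trend from which to judge those groups. They also leave open how a carboxylic acid or a longer chain would fare at this position, and whether fluoro placed elsewhere on the core of compound 1 would move the number in the same direction.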